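This account rests on a few compounds, and the source may have more. Where it says the series, first, only, none or still open, it means among the compounds named here.

Compound 1 `COc1cc(-c2nnc3n2NC(c2ccco2)C(C(=O)c2cccs2)S3)cc(OC)c1OC` gives 64100 nM in a functional assay on HepG2 cells (Homo sapiens) for cytotoxicity, read by MTT assay, with a stated time of 48 h; on this read-out higher numbers stand for weaker inhibition and lower numbers for stronger inhibition. Compound 2 `COc1cc(-c2nnc3n2NC(c2ccco2)C(C(=O)c2ccc(C(F)(F)F)cc2)S3)cc(OC)c1OC` is known in this assay only by a limit, > 100000 nM. The step of an at least 1.5-fold higher number from compound 1 to compound 2 (0.19 log units; that floor lies within the scatter) is therefore an open-ended one, and nothing more can be said about where compound 2 stands than that it sits at that limit (the limit of > 100000 nM in this assay, at which 1 of the 2 values shown sits).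

Compound 3 `COc1cc(-c2nnc3n2NC(c2ccco2)C(C(=O)c2ccc(-c4ccccc4)cc2)S3)cc(OC)c1OC` differs from compound 2 by phenyl in place of trifluoromethyl on an aromatic carbon. For the measured compounds named here, no measured step covers this exchange, and the only step that touches the carbonyl substituent, an at least 1.5-fold higher number from compound 1 to compound 2 (0.19 log units; that floor lies within the scatter), ends at a limit rather than a number. The expectation for compound 3 can therefore rest only on the fact that compound 2 already sits at the limit, so a further change that stays within the scatter or lands at the limit again is expected: a number no higher from compound 2 to compound 3 (the limit leaves the size open).

Compound 3 is estimated at 100000 nM, with a range from 30000 nM to 400000 nM, in this assay.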

Compound 3, half-maximal inhibitory concentration: > 100000 nM
Compound 3: no number, only a limit; the forecaster's own chance of this, stated with the estimate: 55%; the middle value sits exactly at the limit.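

In this assay compound 3 is known only by a limit, > 100000 nM, so the step that exchanges trifluoromethyl for phenyl cannot be read in size. Measured from the thiophen-2-yl group on the carbonyl carbon, 4-phenylphenyl gives an at least 1.5-fold higher number from compound 1 to compound 3 (0.19 log units; that floor lies within the scatter), an open-ended step whose floor says little on its own. What the result adds is that two different groups at this place, one with a ring and one without, now end at the same limit and not at a number: the limit of > 100000 nM in this assay, at which 2 of the 3 values shown sit.

Of the three compounds shown, only compound 1 carries a number, so how far the values at this place reach past the limit stays open. Also open, going by these compounds, is whether an amine or a carboxylic acid at this place would give a readable value in this assay.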